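Alkyl in place of arylmethyl on the sulfonamide nitrogen

This account rests on a few compounds, and the source may have more. Where it says the series, first, only, none or still open, it means among the compounds named here.

Values in a functional assay on HCT-116 cells (Homo sapiens) for inhibition, read by MTT assay, with a stated time of 72 h (a higher number here means a weaker inhibitor, a lower number a stronger inhibitor), for the measured compounds:
compound 1, `CCOC(=O)c1oc2ccc(N(Cc3ccccc3)S(=O)(=O)c3ccc(Cl)cc3)cc2c1C`: 23200 nM
compound 2, `CCOC(=O)c1oc2ccc(N(Cc3ccc(Cl)cc3)S(=O)(=O)c3ccc(Cl)cc3)cc2c1C`: 9640 nM
compound 3, `CCOC(=O)c1oc2ccc(N(CC3CCCCC3)S(=O)(=O)c3ccc(Cl)cc3)cc2c1C`: > 40000 nM

Compound 3 sits at the limit of > 40000 nM in this assay, at which 1 of the 3 values shown sits; its entry is a limit of the assay and not a number. Compound 2 gives the lowest number of the three, by a 2.4-fold lower number from compound 1 to compound 2 (0.38 log units; beyond the scatter) and an at least 4.1-fold higher number from compound 2 to compound 3 (0.61 log units; beyond the scatter). Compound 4, `CCOC(=O)c1oc2ccc(N(C(C)C)S(=O)(=O)c3ccc(Cl)cc3)cc2c1C`, is not yet measured; it differs from compound 3 by isopropyl in place of cyclohexylmethyl on a sulfonamide nitrogen. The measured steps that bear on this change are those that alter the group on the same nitrogen: an at least 1.7-fold higher number from compound 1 to compound 3 (0.23 log units; that floor lies within the scatter) and an at least 4.1-fold higher number from compound 2 to compound 3 (0.61 log units; beyond the scatter). Within the data shown here, both run from an arylmethyl group to a saturated one and end at the limit, so no measured pair compares two saturated groups with each other, and nothing shows how far past the limit compound 3 lies. Compound 4 keeps a saturated group at that position, so in this assay compound 4 is expected to stay near the limit, with the step of a number no higher from compound 3 to compound 4 (the limit leaves the size open) estimated as none beyond the scatter. The estimate for compound 4 is 40000 nM, between 15000 nM and 110000 nM, and a reported limit rather than a number is likely.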

Compound 4, half-maximal inhibitory concentration: > 40000 nM
Compound 4 ended at the assay's limit (the forecaster's own chance of this, stated with the estimate: 60%); the middle value lies on the limit itself.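

Compound 3 and compound 4 carry different saturated groups on the sulfonamide nitrogen, cyclohexylmethyl and isopropyl, yet in this assay both end at the same limit, which is not a number: the limit of > 40000 nM in this assay, at which 2 of the 4 values shown sit. Replacing 4-chlorobenzyl with isopropyl gives an at least 4.1-fold higher number from compound 2 to compound 4 (0.61 log units; beyond the scatter), and replacing benzyl with isopropyl gives an at least 1.7-fold higher number from compound 1 to compound 4 (0.23 log units; that floor lies within the scatter). Removing the ring from the saturated group thus brings no readable value, so among the four compounds only the arylmethyl groups of compound 1 and compound 2 give numbers, and the step from compound 3 to compound 4 cannot be read.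

As far as these compounds go, how far past the limit compound 3 and compound 4 lie remains open. Also open, from the compounds shown here alone, is whether a 4-methoxybenzyl group, or a longer chain ending in an amine, on this nitrogen would give a number.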